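A few compounds are considered here, and "the series" means these few. Any claim that something is new, unique, unknown or untested is made for them only; others in the source may bear on it.

Working notes on the series. Going by the values given here, in an assay on isolated protein for inhibition of proto-oncogene tyrosine-protein kinase receptor Ret (Homo sapiens), read by radiometric assay and 33P incorporation, in the presence of a further agent that is not named here (a lower number here means a stronger inhibitor, a higher number a weaker inhibitor), compound 1 `Nc1ncnc2c1c(-c1cc(C3CC3)on1)nn2C1CCCCC1` gives 2 nM, the lowest of the three numbers measured so far. Compound 3 `CC(C)c1cc(-c2nn(C(C)C)c3ncnc(N)c23)no1` gives 41 nM and compound 2 `CC(C)n1nc(-c2cc(-c3ccccc3)on2)c2c(N)ncnc21` gives 190 nM. Among the compounds with values here, the only step between measured compounds that differ in one place is a 4.6-fold lower number from compound 2 to compound 3 (0.67 log units; beyond the scatter), and it concerns a group on an aromatic carbon, not the group on the aromatic nitrogen. Compound 4 `CCCCCCCn1nc(-c2cc(C3CC3)on2)c2c(N)ncnc21` differs from compound 1 by heptyl in place of cyclohexyl on an aromatic nitrogen. Within the data shown here, no measured step bears on this change, so the expectation rests on the change itself and is uncertain; a modest weakening is expected, a 5.0-fold higher number from compound 1 to compound 4 (0.70 log units; beyond the scatter). Compound 4 is therefore estimated at 10 nM, with a range of 2 nM to 60 nM.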

Compound 4, half-maximal inhibitory concentration: 96 nM
The estimate for compound 4 lay 9.6-fold (0.98 log units) below the measured number, and the stated range ends below it.
By their numbers in this assay, from the lowest: compound 1; then compound 3; then compounds 4 and 2 (each within the scatter of the next).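

Heptyl in place of cyclohexyl on the aromatic nitrogen gives a 48-fold higher number from compound 1 to compound 4 (1.68 log units; beyond the scatter), the first reading at this position with the rest of the molecule held constant. The loss is large even though both groups are all carbon, with no hydrogen-bond donors or acceptors, so this position does not accept every such group alike. Nothing available accounts for the loss.

As far as these compounds go, whether it follows from losing the ring or from the length of the chain remains open. A butyl chain, a cyclopentyl ring or a piperidine ring bearing an amine would help separate these.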